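The source may hold more compounds than are shown below. What is called first, only, known or untested is meant among the compounds shown, and "the series" means these compounds.

Compound 1 `COc1ccc(/C=C\C(=O)O)c(OCc2cn(-c3ccccc3F)nn2)c1CC=C(C)C` gives 12400 nM in a functional assay on A-431 cells (Homo sapiens) for cytotoxicity, read by MTT assay, with a stated time of 24 h (on this read-out higher numbers stand for weaker inhibition and lower numbers for stronger inhibition), the lowest number of the three measured, though its gap to compound 3 `COc1ccc(/C=C\C(=O)O)c(OCc2cn(-c3cccc([N+](=O)[O-])c3)nn2)c1CC=C(C)C` at 18400 nM lies within the scatter; compound 2 `COc1ccc(/C=C\C(=O)O)c(OCc2cn(-c3ccccc3I)nn2)c1CC=C(C)C` stands further off at 32700 nM. Compound 4 `COc1ccc(/C=C\C(=O)O)c(OCc2cn(-c3ccccc3C#N)nn2)c1CC=C(C)C` differs from compound 1 by cyano in place of fluoro on an aromatic carbon. Within the data shown here, the only measured step at this same aromatic carbon is a 2.6-fold higher number from compound 1 to compound 2 (0.42 log units; beyond the scatter), a modest rise, while the change of the whole aryl group gives a 1.5-fold higher number from compound 1 to compound 3 (0.17 log units; within the scatter), within the scatter. Neither step involves a cyano group, so the guidance is thin. A modest rise or no step beyond the scatter is therefore expected in this assay, namely a 1.3-fold higher number from compound 1 to compound 4 (0.11 log units; within the scatter). Compound 4 is thus estimated at 16000 nM, with a range from 7000 nM to 36000 nM.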

Compound 4, half-maximal inhibitory concentration: 10300 nM
Compound 4: middle estimate off by 1.6-fold (0.19 log units), on the high side; low and high end bracket the measured number.
By their numbers in this assay, from the lowest: compounds 4, 1, 3 and 2 (each within the scatter of the next, the first and the last beyond it).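

In this assay, cyano in place of fluoro on this aromatic carbon, ortho to a large group, leaves the number within the scatter (a 1.2-fold lower number from compound 1 to compound 4 (0.08 log units; within the scatter)), and the change from the 3-nitrophenyl group also stays within it (a 1.8-fold lower number from compound 3 to compound 4 (0.25 log units; within the scatter)). Cyano in place of iodo on the same carbon is a step beyond the scatter (a 3.2-fold lower number from compound 2 to compound 4 (0.50 log units; beyond the scatter)), so iodo is the only one of these substituents that separates from cyano. No measurement at hand accounts for these numbers. From the compounds shown here alone, what an amine or a carboxylic acid would give on this carbon remains open, as does the effect of cyano elsewhere on the ring.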